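Lengthening the Dialkylamino Group on a Shared Core

The compounds below may be only part of what the source reports. "The series", "measured", "known", "first", "only" and "open" are said of these compounds alone.

Three compounds share one core and differ only in the amine attached to it. In an assay on isolated protein for displacement of a labelled ligand from corticotropin-releasing factor receptor 1 (Homo sapiens) (on this read-out higher numbers stand for weaker inhibition and lower numbers for stronger inhibition), compound 1 `CCCCC(CC)Nc1nc(C)nc2c(-c3ccc(Cl)cc3Cl)c(C)nn12` gives 1.6 nM, compound 2 `CCN(CC)c1nc(C)nc2c(-c3ccc(Cl)cc3Cl)c(C)nn12` gives 1.2 nM and compound 3 `CCCC(CC)Nc1nc(C)nc2c(-c3ccc(Cl)cc3Cl)c(C)nn12` gives 1.2 nM. Compound 2 stands level with compound 3, the two together showing the lowest numbers of the three, with compound 1 the furthest away. The step of a 1.3-fold lower number from compound 1 to compound 2 (0.12 log units; within the scatter) and the step of no change at the digits printed from compound 2 to compound 3 (within the scatter) show that swapping one amine for another barely moves this assay. Compound 4 `CCCN(CCC)c1nc(C)nc2c(-c3ccc(Cl)cc3Cl)c(C)nn12` continues the series: dipropylamino in place of diethylamino on an aromatic carbon. Since a 1.3-fold lower number from compound 1 to compound 3 (0.12 log units; within the scatter) and no change at the digits printed from compound 2 to compound 3 (within the scatter) both lay within the scatter, compound 4 is expected to stay close, with a step of a 1.1-fold higher number from compound 2 to compound 4 (0.03 log units; within the scatter). Compound 4 is estimated at 1.3 nM, between 0.5 nM and 3.5 nM.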

Compound 4, inhibition constant: 0.6 nM
Compound 4: middle estimate off by 2.2-fold (0.34 log units), on the high side; the measured number falls inside the stated range.
By their numbers in this assay, from the lowest: compounds 4, 2, 3 and 1 (each within the scatter of the next, the first and the last beyond it).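

At this position on the shared core, dipropylamino stays within the scatter of two other amines in this assay, with a 2.0-fold lower number from compound 2 to compound 4 (0.30 log units; within the scatter) for diethylamino and a 2.0-fold lower number from compound 3 to compound 4 (0.30 log units; within the scatter) for (1-ethylbutyl)amino. Within the data shown here, the comparison with (1-ethylpentyl)amino gives a 2.7-fold lower number from compound 1 to compound 4 (0.43 log units; beyond the scatter) as the first step to pass beyond the scatter, though only modestly. No measurement here explains that separation. Still open, as far as these compounds go, is how a longer symmetrical chain such as dibutylamino, or a ring amine such as morpholine, would behave at this position.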